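A few compounds are considered here, and "the series" means these few. Any claim that something is new, unique, unknown or untested is made for them only; others in the source may bear on it.

Working notes on the series. Compound 1 `CC1CCN(c2c(S(=O)(=O)c3ccccc3)cnc3ccccc23)CC1` gives 89.2% in an assay on isolated protein for displacement of a labelled ligand from metabotropic glutamate receptor 5 (Homo sapiens), with a stated time of 60 min, tested at 1 uM; on this read-out lower numbers stand for less inhibition and higher numbers for more inhibition at the one concentration tested (going by the name of the read-out). Compound 2 `CC1CCN(c2c(S(=O)(=O)c3ccccc3)cnc3ccc(Cl)cc23)CC1` gives 59% and stands lowest of the three numbers measured, with compound 3 `Cc1ccc2ncc(S(=O)(=O)c3ccccc3)c(N3CCC(C)CC3)c2c1` at 67% within the scatter of it; the step of a number 30.2 percentage points lower from compound 1 to compound 2 (beyond the scatter) is the only one beyond the scatter that separates compound 2 from another compound. Compound 4 `CC1CCN(c2c(S(=O)(=O)c3ccc(Cl)cc3)cnc3ccc(Cl)cc23)CC1` differs from compound 2 by chloro in place of hydrogen on an aromatic carbon. Within the data shown here, the one measured step of the same kind, a number 30.2 percentage points lower from compound 1 to compound 2 (beyond the scatter), sat on the shared core rather than on this ring, so it bears only loosely; the methyl steps a number 22.2 percentage points lower from compound 1 to compound 3 (beyond the scatter) and a number 8 percentage points higher from compound 2 to compound 3 (within the scatter) add little. The step from this change is expected to be a number 11 percentage points lower from compound 2 to compound 4 (beyond the scatter). This expectation is held only loosely. Compound 4 is therefore estimated at 48%, ranging from 22% to 74%.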

Compound 4, a percentage reported as inhibition, at one concentration (the size of the read-out at that concentration, not a potency): 92%
The estimate for compound 4 lay 44 percentage points below the measured number; the whole stated range lies below it.
By their numbers in this assay, from the lowest: compounds 2 and 3 (each within the scatter of the next); then compounds 1 and 4 (each within the scatter of the next).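

In this assay the change from phenyl to 4-chlorophenyl gives a number 33 percentage points higher from compound 2 to compound 4 (beyond the scatter) and so runs opposite to the same hydrogen-to-chloro change on the shared core, a number 30.2 percentage points lower from compound 1 to compound 2 (beyond the scatter) in that case. Across these two steps the direction of a chloro step depends on its place, and the step on the shared core does not carry over to this ring. Nothing available accounts for the reversal. Open, on these data alone, is whether a methoxy group or an amine at this position would give a similar step. Also open, as far as these compounds go, is whether 4-chlorophenyl gives such a step on the core of compound 1.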